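A Shorter Path to the Hydroxycarbamoyl Group

The source may hold more compounds than are shown below. What is called first, only, known or untested is meant among the compounds shown, and "the series" means these compounds.

Of the compounds shown here, three have been measured in an assay on cells for inhibition of protein deacetylase HDAC6 (Homo sapiens), read by fluorescence, with stated times of 15 min and 60 min; on this read-out lower numbers stand for stronger inhibition and higher numbers for weaker inhibition. Compound 1, with the structure `O=C(CCCCCNC(=O)c1cc(-c2ccc(F)cc2)[nH]n1)NO`, gives 29 nM in this assay, which is the second highest of the three numbers. Compound 2, with the structure `Cc1cc(-c2ccc(F)cc2)nn1Cc1ccc(C(=O)NO)cc1`, gives 8 nM, a markedly lower number than that of compound 1 and beyond the usual scatter. Compound 3, with the structure `O=C(NO)c1ccc(Cn2nc(Cc3ccccc3)cc2-c2ccc(F)cc2)cc1`, gives 420 nM, a far higher number than that of compound 1, again beyond the scatter. Compound 1 therefore sits between its two neighbours, closer to compound 2 than to compound 3.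

The unmeasured compound 4 has the structure `O=C(CCCCNC(=O)c1cc(-c2ccc(F)cc2)[nH]n1)NO`. It differs from compound 1 in one place: hydroxycarbamoyl in place of (hydroxycarbamoyl)methyl on a saturated chain carbon, four bonds along the chain from an amide-type nitrogen. Everything else in the molecule is unchanged.

Going by the values given here, because compound 1 gives 29 nM in this assay and no measured pair shows the effect of this particular change, the expectation rests on compound 1 alone. The step from compound 1 to compound 4 is expected to be a modest rise in the number, a 2.1-fold higher number from compound 1 to compound 4 (0.32 log units; beyond the scatter), near the edge of the usual scatter. Compound 4 is estimated at 60 nM, with a likely range from 20 nM to 200 nM.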

Compound 4, half-maximal inhibitory concentration: 275 nM
The estimate for compound 4 lay 4.6-fold (0.66 log units) below the measured number, and the stated range ends below it.
By their numbers in this assay, from the lowest: compound 2; then compound 1; then compounds 4 and 3 (each within the scatter of the next).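

In this assay, the change from (hydroxycarbamoyl)methyl to hydroxycarbamoyl on a saturated chain carbon, four bonds along the chain from an amide-type nitrogen, gives a 9.5-fold higher number from compound 1 to compound 4 (0.98 log units; beyond the scatter). Going by these compounds alone, this is the first comparison here in which only one place in the molecule differs, so it isolates an effect that the three earlier compounds could not show: with the rest of the molecule unchanged, the shorter chain gives much weaker inhibition. The length of the chain carrying the hydroxycarbamoyl group is therefore not a minor detail in this series, at least between these two compounds, and the data at hand offer no explanation for the size of this step.

With only these two chain lengths shown, it remains open whether a longer chain ending in hydroxycarbamoyl would continue the trend, level off or reverse it. Also open, on these data alone, are how a carboxylic acid would compare with hydroxycarbamoyl at the end of the chain of compound 1, and whether the same shortening would have a similar effect on a different core.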